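Alkyl variation on the ring amide nitrogen: compound 4

The compounds below may be only part of what the source reports. "The series", "measured", "known", "first", "only" and "open" are said of these compounds alone.

Measured so far:
compound 1 `O=C(O)c1cc(-c2cccc(COc3ccc4c(c3)CN(Cc3ccc(C(F)(F)F)cc3)C4=O)c2)ccc1Cl` — 350 nM
compound 2 `CC(C)CN1Cc2cc(OCc3cccc(-c4ccc(Cl)c(C(=O)O)c4)c3)ccc2C1=O` — 100 nM
compound 3 `O=C(O)c1cc(-c2cccc(COc3ccc4c(c3)CN(C3CC3)C4=O)c2)ccc1Cl` — 220 nM

In an assay on HEK293 cells for positive allosteric modulation of metabotropic glutamate receptor 2 (Rattus norvegicus), read by thallium flux (a lower number here means that less compound is needed, a higher number that more compound is needed for the effect), compound 3 gives 220 nM, the second highest of the three numbers: the step of a 1.6-fold lower number from compound 1 to compound 3 (0.20 log units; within the scatter) stays within the scatter, whereas a 2.2-fold higher number from compound 2 to compound 3 (0.34 log units; beyond the scatter) lies beyond it. Compound 4 `CCCN1Cc2cc(OCc3cccc(-c4ccc(Cl)c(C(=O)O)c4)c3)ccc2C1=O` carries the change (propyl in place of cyclopropyl on an amide-type nitrogen in a ring). The step that bears on it most directly is the one from isobutyl to cyclopropyl just named, where the chain gave the lower number; the step of a 3.5-fold lower number from compound 1 to compound 2 (0.54 log units; beyond the scatter) points the same way for isobutyl against the larger aromatic group. Propyl, like isobutyl, is a chain without a ring, so a modest move toward the number of compound 2 is expected, without going past what the measured steps span. For compound 4 the estimated value is 150 nM, within 70 nM to 320 nM. The expected step is a 1.5-fold lower number from compound 3 to compound 4 (0.17 log units; within the scatter).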

Compound 4, half-maximal effective concentration: > 10000 nM
Compound 4: no number, only a limit (the forecaster's own chance of this, stated with the estimate: 2%); middle value at least 66-fold (1.82 log units) from the limit.
By their numbers in this assay, from the lowest: compound 2; then compounds 3 and 1 (each within the scatter of the next). At a limit, above all of these: compound 4.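

In this assay compound 4 gives no number, only a limit: the limit of > 10000 nM in this assay, at which 1 of the 4 values shown sits.

Propyl in place of cyclopropyl on the amide-type nitrogen leaves the heavy-atom count unchanged, yet it gives an at least 45-fold higher number from compound 3 to compound 4 (1.65 log units; beyond the scatter), so at this position the open chain cannot stand in for the three-membered ring. Loss of a single methyl from the isobutyl group gives an at least 100-fold higher number from compound 2 to compound 4 (2.00 log units; beyond the scatter), and the comparison with the 4-(trifluoromethyl)benzyl group gives an at least 28-fold higher number from compound 1 to compound 4 (1.45 log units; beyond the scatter), so among the four groups shown the loss is confined to propyl and does not follow group size.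

The compounds shown do not tell whether the loss is specific to propyl or extends to other short chains, such as ethyl or n-butyl, on the same nitrogen. They also give no cause for the gap between propyl and isobutyl.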